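Chloro Substitution on the Benzyl Ring of a Squaramide Series

The source may report more compounds than this note shows. Statements on the series, on what has been measured and on what is new or still open speak of the compounds shown alone.

Of the compounds shown here, three of a shared core have been measured in a functional assay for inhibition, with Rattus norvegicus as the target; on this read-out higher numbers stand for weaker inhibition and lower numbers for stronger inhibition. Compound 1 `CCC(C)(C)/N=c1\c(O)c(O)\c1=N/Cc1ccc(C)cc1C` gives 530 nM. Compound 2 `CC(C)(C)/N=c1\c(O)c(O)\c1=N/Cc1ccc(C#N)cc1` carries a different core, and the difference between the two cores is not broken down here; in this assay compound 2 gives 270 nM. Compound 3 `CCC(C)(C)/N=c1\c(O)c(O)\c1=N/Cc1c(C)cc(C)cc1Cl` gives 200 nM in this assay.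

Compounds 1 and 3 differ in one place, (chloro in place of hydrogen on an aromatic carbon), and this change produced a 2.7-fold lower number from compound 1 to compound 3 (0.42 log units; beyond the scatter). Compound 4 `CC(C)(C)/N=c1\c(O)c(O)\c1=N/Cc1ccc(C#N)cc1Cl` has not yet been measured. Going by the values given here, it is related to compound 2 by chloro in place of hydrogen on an aromatic carbon, which is the same kind of change as the one from compound 1 to compound 3, though the surroundings differ: in compound 3 the chloro sits meta to two methyl groups, whereas in compound 4 it sits meta to a cyano group.

The value of compound 2 lies close to that of compound 3 and is within the scatter of both other measured compounds, so no order among the three is claimed. For compound 4 a step of a 2.3-fold lower number from compound 2 to compound 4 (0.35 log units; beyond the scatter) is expected in this assay, because the same kind of change gave a 2.7-fold lower number from compound 1 to compound 3 (0.42 log units; beyond the scatter). The expectation rests on a single precedent, so it is held loosely. Compound 4 is estimated to give 120 nM in this assay, with a range from 50 nM to 300 nM expected.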

Compound 4, half-maximal inhibitory concentration: 140 nM
For compound 4 the middle estimate is 1.2-fold (0.07 log units) below the measured one; the measured number falls inside the stated range.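

Placed on the core of compound 2, chloro in place of hydrogen on an aromatic carbon gives in this assay a 1.9-fold lower number from compound 2 to compound 4 (0.29 log units; within the scatter), so this step taken alone cannot be told apart from repeat measurements of a single compound. Its direction matches that of the earlier step, and the two steps do not differ in size beyond what two such steps would scatter, which is consistent with the change carrying from the core of compound 1 to the core of compound 2: the same change on two cores in this assay, a 2.7-fold lower number (0.42 log units; beyond the scatter) from compound 1 to compound 3 and a 1.9-fold lower number (0.29 log units; within the scatter) from compound 2 to compound 4, 1.4-fold (0.14 log units) apart, within the scatter of two such steps

This does not amount to a rule for the series, since it rests on two pairs of compounds in one assay, one of whose steps lies within the scatter, and it gives no reason for the size of either step.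

The compounds shown leave open whether fluoro or bromo in the same place would give a step of similar size to that of chloro, and whether a methoxy group or an amine would do the same. They also leave open whether the chloro step would hold on a core carrying a carboxylic acid or a longer chain.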